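The compounds below may be only part of what the source reports. "The series", "measured", "known", "first", "only" and "open" are said of these compounds alone.

Working notes on the series. The shared core carries a substituted phenyl on one side and a piperazine-bearing methylene on the other, and the four members differ only in the groups on those two ends. Compound 1 is `O=C1CC(c2ccccc2F)C(=O)N1CN1CCN(c2ccc(Cl)cc2)CC1`, compound 2 is `O=C1CC(c2ccccc2F)C(=O)N1CN1CCN(c2cccc(C(F)(F)F)c2)CC1`, compound 3 is `O=C1CC(c2ccccc2Br)C(=O)N1CN1CCN(c2cccc(Cl)c2)CC1`, and the unmeasured compound 4 is `O=C1CC(c2ccccc2Br)C(=O)N1CN1CCN(C2CCCCC2)CC1`.

In a functional assay on the whole organism (strain CF-1 albino) with Mus musculus as the target, with a stated time of 4 h (a lower number here means that less compound is needed, a higher number that more compound is needed for the effect), compound 1 gives 100 mg/kg. Compound 2 gives 100 mg/kg. Compound 3 gives 100 mg/kg, so compound 3 stands level with compounds 1 and 2 at the digits shown; its nearest neighbour is compound 1 and its furthest is compound 2, both within the scatter.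

The step to compound 4 is cyclohexyl in place of 3-chlorophenyl on an amine nitrogen in a ring. Within the data shown here, the one measured step at the same place, no change at the digits printed from compound 1 to compound 2 (within the scatter), shows no change within the scatter when one substituted phenyl replaces another on the amine nitrogen in the ring. Among the measured compounds shown here, no measured step replaces a six-membered aromatic ring with a six-membered non-aromatic ring at that position, so the bearing of the measured data on this change is limited. Given that the series has so far been flat in this assay, the expectation for the step of no change at the digits printed from compound 3 to compound 4 (within the scatter) is no change beyond the scatter, with the range widened for the unprecedented ring type. Compound 4 is therefore expected to give 100 mg/kg, estimated between 50 mg/kg and 300 mg/kg.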

Compound 4, minimum effective dose: 100 mg/kg
Compound 4: the middle estimate sits on the measured number at the digits printed, and the stated range covers the measured number.
By their numbers in this assay, from the lowest: compounds 1, 2, 3 and 4 (each within the scatter of the next).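

In this assay, among these compounds, cyclohexyl in place of 3-chlorophenyl on an amine nitrogen in a ring gives no change at the digits printed from compound 3 to compound 4 (within the scatter), the first reading at this position in which a six-membered non-aromatic ring of carbon only stands where a six-membered aromatic ring stood. The earlier step, no change at the digits printed from compound 1 to compound 2 (within the scatter), exchanged only one substituted phenyl for another, so the flat reading at this position now extends to an unsubstituted non-aromatic ring and to a group without chlorine, though only for this one pair. Nothing measured alongside these compounds offers an explanation for this result.

The compounds shown leave open whether the same flat reading would hold with an open-chain group on this nitrogen, such as a longer alkyl chain, or with a ring carrying an amine or a carboxylic acid. They also leave open what the fluoro- or bromo-substituted phenyl on the other end of the shared core contributes on its own, as no step shown changes that end alone.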